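Swapping the Heme-Directed Group in a Stilbene Series

The compounds below may be only part of what the source reports. "The series", "measured", "known", "first", "only" and "open" are said of these compounds alone.

Measured compounds:
compound 1 `O=S(=O)(C(F)F)N1CCN(c2ccc(/C=C/c3cc(F)cc(Cn4ccnc4)c3)cc2)CC1` – 5 nM
compound 2 `O=S(=O)(C1CC1)N1CCN(c2ccc(/C=C/c3cc(F)cc(Cn4ccnc4)c3)cc2)CC1` – 34 nM

In an assay on cells for inhibition of steroid 17-alpha-hydroxylase/17,20 lyase (Homo sapiens), read by scintillation counting, with stated times of 60 min and 4 h (a lower number here means a stronger inhibitor, a higher number a weaker inhibitor), compound 1 gives 5 nM and compound 2 gives 34 nM. Compound 2 therefore stands at the higher end of the two numbers, with a 6.8-fold higher number from compound 1 to compound 2 (0.83 log units; beyond the scatter) separating it from compound 1; that step concerns only the group on the sulfonyl sulfur and leaves the rest of the shared core untouched.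

Compound 3 `O=S(=O)(C1CC1)N1CCN(c2ccc(/C=C/c3cc(F)cc(-c4ccncc4)c3)cc2)CC1` has not been measured. It differs from compound 2 by pyridin-4-yl in place of (1H-imidazol-1-yl)methyl on an aromatic carbon. Among the compounds with values here, no measured step touches this position, so the step from compound 1 to compound 2 does not bear on it, and the expectation rests on the value of compound 2 alone and on the size of the change, which replaces one aromatic heterocycle by another of the same heavy-atom count. Compound 3 is expected to give a moderately higher number, a 2.4-fold higher number from compound 2 to compound 3 (0.37 log units; beyond the scatter), with an estimate of 80 nM and a range from 15 nM to 500 nM.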

Compound 3, half-maximal inhibitory concentration: 1 nM
For compound 3 the middle estimate is 80-fold (1.90 log units) above the measured one; measured number below the stated range.
By their numbers in this assay, from the lowest: compound 3; then compound 1; then compound 2.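

In this assay, this position on the aromatic carbon proves highly sensitive: with the cyclopropyl group on the sulfonyl sulfur held constant, the change gives a 34-fold lower number from compound 2 to compound 3 (1.53 log units; beyond the scatter), a large step. It also shows that the (1H-imidazol-1-yl)methyl group is not needed for low-nanomolar inhibition here, since pyridin-4-yl takes its place and compound 3 gives 1 nM. The two groups have the same heavy-atom count, so that count does not predict the outcome, and nothing available explains the step.

The change replaces the ring and removes the methyl link in one step, so the compounds shown cannot separate those two effects; (pyridin-4-yl)methyl or pyridin-3-yl would bear on that question. They also leave open whether pyridin-4-yl has a similar effect with difluoromethyl on the sulfonyl sulfur.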